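Replacing a butynyl ester with a carbamoyl group

The compounds below may be only part of what the source reports. "The series", "measured", "known", "first", "only" and "open" are said of these compounds alone.

Measured compounds:
compound 1, `C#CCCOC(=O)/C=C(C)/C=C/CC(C)CCCC(C)(C)OC`, 5.2;
compound 2, `CCOC(=O)/C=C(C)/C=C/CC(C)CCC(SCC)C(C)C`, 6.9;
compound 3, `CC(=O)OC(C)(C)CCCC(C)C/C=C/C(C)=C/C(=O)OC(C)C`, 5.98.

Three esters of the same dienoic acid were measured in a physicochemical assay for lipophilicity; a lower number here means a more polar compound, a higher number a more lipophilic compound. Compound 1 gives 5.2 and stands lowest of the three numbers. Its nearest neighbour is compound 3 with 5.98, a number beyond the scatter above it, and furthest is compound 2 with 6.9, also beyond the scatter. Among the compounds with values here, no pair among them differs in only one place, so no single step is available from the measured set.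

Compound 4, `COC(C)(C)CCCC(C)C/C=C/C(C)=C/C(N)=O`, is not yet measured. It differs from compound 1 in one place: amino in place of (but-3-yn-1-yl)oxy on a carbonyl carbon. A (but-3-yn-1-yl)oxy group with one hydrogen-bond acceptor leaves, and an amino group with one hydrogen-bond donor enters on the carbonyl carbon. For compound 4 a large step downward in this assay is expected, well beyond the scatter, estimated as a number 2.50 log units lower from compound 1 to compound 4 (beyond the scatter). Compound 4 is thus expected to come in at 2.7, within a range from 2 to 3.5.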

Compound 4, partition coefficient: 3.52
Estimate against measurement, compound 4: 0.82 log units below; the measured number lies above the stated range.
By their numbers in this assay, from the lowest: compound 4; then compound 1; then compound 3; then compound 2.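

Within the data shown here, replacing the (but-3-yn-1-yl)oxy group on the carbonyl carbon with amino gives the first comparison here in which only one place changes: in this assay the step is large, a number 1.68 log units lower from compound 1 to compound 4 (beyond the scatter), with the rest of the structure unchanged. This single change removes the triple bond and exchanges a hydrogen-bond acceptor for a hydrogen-bond donor, so the step cannot be divided among these differences. Nothing available explains the size of the step.

Going by these compounds, it remains open where a methylamino group, a dimethylamino group or a hydroxyl group, which would give the carboxylic acid, would fall on the same carbonyl carbon. On these data alone, it is also open whether a carbamoyl group in place of the ester of compound 2 or compound 3 would give a step of similar size.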